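A few compounds are considered here, and "the series" means these few. Any claim that something is new, unique, unknown or untested is made for them only; others in the source may bear on it.

Measured so far:
compound 1, `O=C(CCC1=CCN(CCCc2ccc(Br)cc2)C1=O)NO` — 2210 nM
compound 2, `CC(C)(C)c1ccc(CCCN2CC=C(CCC(=O)NO)C2=O)cc1` — 2210 nM

Compound 1 carries a 4-bromophenyl group on the chain that hangs from the ring nitrogen of the shared core. In a functional assay on MDA-MB-231 cells (Homo sapiens) for inhibition, read by sulforhodamine B assay (a higher number here means a weaker inhibitor of growth, a lower number a stronger inhibitor of growth), compound 1 gives 2210 nM, and compound 2 gives 2210 nM; the two stand level within the scatter. For the measured compounds named here, the only measured step, no change at the digits printed from compound 1 to compound 2 (within the scatter), came from swapping one group for another on the aromatic ring, and it moved nothing.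

Compound 3 `Cc1ccccc1CCCN1CC=C(CCC(=O)NO)C1=O` differs from compound 1 in one place: 2-methylphenyl in place of 4-bromophenyl on a saturated chain carbon, three bonds along the chain from an amide-type nitrogen in a ring. Going by the values given here, no measured step covers this exact change, since the step between compound 1 and compound 2 kept the aromatic ring and altered only its substituent. Among the compounds with values here, still, the one step available gives no sign that the aromatic end of this chain steers growth inhibition, so no shift beyond the scatter is expected in this assay. Compound 3 is therefore estimated at 2200 nM, with a range of 1000 nM to 5000 nM, an expected step of a 1.0-fold lower number from compound 1 to compound 3 (0.00 log units; within the scatter).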

Compound 3, concentration for 50% growth inhibition: 2210 nM
Compound 3: the middle estimate sits 1.0-fold (0.00 log units) below what was measured; the range from low to high includes it.
By their numbers in this assay, from the lowest: compounds 1, 2 and 3 (each within the scatter of the next).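

Replacing 4-bromophenyl with 2-methylphenyl on the chain gives no change at the digits printed from compound 1 to compound 3 (within the scatter) in this assay. This change goes further than the earlier step: the bromine leaves the ring and a methyl group enters under a different name and place on it, yet the reading stays level. Across these compounds, then, the aromatic end of the chain tolerates three different substituted phenyl groups in this assay, and no measurement shown here offers an explanation for that.

All three compounds keep a carbon-only aromatic ring at the end of the chain, so they cannot show whether that ring matters at all. A cyclohexyl group in its place, an amine or carboxylic acid on the ring, or a longer chain remains an open question.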